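N-methylation of the glycine amide linker in this series

The source may report more compounds than this note shows. Statements on the series, on what has been measured and on what is new or still open speak of the compounds shown alone.

Compound 2 `CN1CCC(N2CCN(C(=O)CNC(=O)c3nc4ccccc4n3Cc3ccccc3)CC2)CC1` carries the extended linker; in a functional assay on CHO cells for antagonist activity at B1 bradykinin receptor (Macaca fascicularis), read by FLIPR and calcium flux (a lower number here means a stronger inhibitor, a higher number a weaker inhibitor), compound 2 gives 686 nM, the only number shown for the set. Compound 1 `CN1CCC(N2CCN(C(=O)c3nc4ccccc4n3Cc3ccccc3)CC2)CC1` returns only a limit in this assay, > 5000 nM. Compound 3 `CN1CCC(N2CCN(C(=O)CN(C)C(=O)c3nc4ccccc4n3Cc3ccccc3)CC2)CC1` differs from compound 2 by methyl in place of hydrogen on an amide-type nitrogen. No step of this kind has been measured among these compounds, so its direction is open; a change of modest size in this assay, tending toward weaker inhibition, is expected. Compound 3 is estimated at 1100 nM in this assay, within 300 nM to 4000 nM, the expected step being a 1.6-fold higher number from compound 2 to compound 3 (0.21 log units; within the scatter).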

Compound 3, half-maximal inhibitory concentration: 268 nM
Estimate against measurement, compound 3: 4.1-fold (0.61 log units) above, outside the stated range (below it).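

In this assay, methyl in place of hydrogen on the amide-type nitrogen gives a 2.6-fold lower number from compound 2 to compound 3 (0.41 log units; beyond the scatter). Going by these compounds alone, this is the first measured step at this position: the amide hydrogen is not required for activity in this pair, and the methyl goes with stronger inhibition. Nothing measured here gives a cause for the step.

As far as these compounds go, whether an ethyl group or a longer chain on this nitrogen continues the same direction remains open. Also open, from the compounds shown here alone, is whether the gain from methyl carries over to compounds with a different group in place of the benzyl.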